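The source may report more compounds than this note shows. Statements on the series, on what has been measured and on what is new or still open speak of the compounds shown alone.

Measured so far in a functional assay on CHO cells with adenosine receptor A1 (Homo sapiens) as the target, read by cAMP accumulation and immunoassay, with a stated time of 6 min, tested at 0.01 uM; a higher number here means a weaker effect of the compound at the concentration tested, a lower number a stronger effect:
compound 1 `Nc1scc(CN2CCN(c3ccc(Cl)c(C(F)(F)F)c3)CC2)c1C(=O)c1ccc(Cl)cc1` gives -2.5%
compound 2 `Nc1scc(CN2CCN(c3ccc(F)c(Cl)c3)CC2)c1C(=O)c1ccc(Cl)cc1` gives 4.2%

Compound 2 stands highest of the two numbers, its nearest neighbour being compound 1, from which it differs by a number 6.7 percentage points higher from compound 1 to compound 2 (within the scatter). The next compound, compound 3 `Nc1scc(CN2CCN(c3cccc(Cl)c3)CC2)c1C(=O)c1ccc(Cl)cc1`, differs from compound 2 by hydrogen in place of fluoro on an aromatic carbon. Among the compounds with values here, no measured step removes a fluoro; the only step to hand, a number 6.7 percentage points higher from compound 1 to compound 2 (within the scatter), exchanges the whole aryl group and stays within the scatter, so it bears only loosely. No step beyond the scatter is therefore expected in this assay. For compound 3 the estimate is 3% (range -10% to 16%), an expected step of a number 1.2 percentage points lower from compound 2 to compound 3 (within the scatter).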

Compound 3, a percentage reported as activity, at one concentration (the size of the read-out at that concentration, not a potency): -3.1%
For compound 3 the middle estimate is 6.1 percentage points above the measured one; the measured number falls inside the stated range.
By their numbers in this assay, from the lowest: compounds 3, 1 and 2 (each within the scatter of the next).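

In this assay, hydrogen in place of fluoro on the aromatic carbon ortho to the chloro group gives a number 7.3 percentage points lower from compound 2 to compound 3 (within the scatter), so at this position the fluoro can go without a step beyond the scatter. The 3-chlorophenyl also stays within the scatter of the 4-chloro-3-(trifluoromethyl)phenyl, with a number 0.6 percentage points lower from compound 1 to compound 3 (within the scatter), so these aryl groups are not told apart at this single concentration. No measurement at hand offers an explanation for these numbers. From the compounds shown here alone, whether a methoxy or an amine on this carbon would give a step beyond the scatter stays open, as does the effect of replacing the chloro.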